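Working notes: from compound 3 to compound 4

The source may hold more compounds than are shown below. What is called first, only, known or untested is meant among the compounds shown, and "the series" means these compounds.

Measured so far in a functional assay on MOLT-4 cells (Homo sapiens) for inhibition, read by sulforhodamine B assay, with a stated time of 48 h; on this read-out lower numbers stand for stronger inhibition of growth and higher numbers for weaker inhibition of growth:
compound 1 `N#C/C(=C\N1CCN(C(=O)c2ccco2)C1=S)C(=O)Nc1ccc(Cl)cc1` gives 17700 nM
compound 2 `N#C/C(=C\N1CCN(C(=O)c2ccco2)C1=S)C(=O)c1ccccc1` gives 43700 nM
compound 3 `O=CN1CCN(c2ccc(Cl)cc2)C1=S` gives 19200 nM

Compound 3 stands second highest of the three numbers. Its nearest neighbour is compound 1, whose value lies within the scatter of compound 3, so no order between the two can be read. Compound 2 is the furthest, and the gap from compound 3 to compound 2 lies beyond the scatter.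

Compound 4 `O=CN1CCN(c2ccc(Cl)c(Cl)c2)C1=S` is not yet measured. It differs from compound 3 in one place: chloro in place of hydrogen on an aromatic carbon. Among the measured compounds shown here, the only measured step in this assay, a 2.5-fold higher number from compound 1 to compound 2 (0.39 log units; beyond the scatter), concerns a different place, a group on a carbonyl carbon, and does not involve the aromatic ring; no measured pair shows a chloro added to that ring. There is thus nothing to support a step in either direction, and compound 4 is expected to stay close to compound 3, within the scatter, as the step of a 1.3-fold lower number from compound 3 to compound 4 (0.11 log units; within the scatter) expresses. Compound 4 is estimated at 15000 nM, with a range from 5000 nM to 45000 nM.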

Compound 4, concentration for 50% growth inhibition: 22800 nM
The estimate for compound 4 lay 1.5-fold (0.18 log units) below the measured number; measured number inside the range.
By their numbers in this assay, from the lowest: compounds 1, 3, 4 and 2 (each within the scatter of the next, the first and the last beyond it).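

In this assay, chloro in place of hydrogen on an aromatic carbon, ortho to a chloro group, gives a 1.2-fold higher number from compound 3 to compound 4 (0.07 log units; within the scatter) and leaves compound 3 and compound 4 without a readable order. Among the compounds shown here, this is the only measured pair that concerns the aromatic ring, and it shows that this added chlorine does not move the number beyond the scatter at this position. No measured evidence bears on this result, so no cause can be given for it.

From the compounds shown here alone, whether an amine or a methoxy group on the same carbon would give a step beyond the scatter remains open. Also open, going by these compounds, is whether the same added chloro would read alike on the chlorine-bearing aromatic ring of compound 1, where the rest of the molecule differs.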